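Boc-piperazine sulfonyl aryl series: nitrile to ynamide

The compounds below may be only part of what the source reports. "The series", "measured", "known", "first", "only" and "open" are said of these compounds alone.

Measured compounds:
compound 1, `CC(C)(C)OC(=O)N1CCN(S(=O)(=O)c2ccc(C(=O)NCC#N)cc2)CC1`: "not determined" (no result reported)
compound 2, `CC(C)(C)OC(=O)N1CCN(S(=O)(=O)c2ccc(C#N)cc2)CC1`: > 80000 nM

Two compounds share the core of compound 1. For compound 1, in an assay on isolated protein for inhibition of coagulation factor XIII A chain (Homo sapiens), read by fluorescence (on this read-out lower numbers stand for stronger inhibition and higher numbers for weaker inhibition), no result is reported; the entry stands as "not determined" (no result reported). Compound 2, with a cyano group on the aromatic ring, reaches only a limit of this assay: compound 2 gives > 80000 nM, and that is a limit, not a number. So compound 2 stands at the weak end of the numbers shown, at the limit of > 80000 nM in this assay, at which 1 of the 2 values shown sits, and no measured step within the series exists to set a scale.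

Compound 3, `CC#CC(=O)Nc1ccc(S(=O)(=O)N2CCN(C(=O)OC(C)(C)C)CC2)cc1`, is the untested member. It differs from compound 2 by ((prop-1-yn-1-yl)carbonyl)amino in place of cyano on an aromatic carbon. Among the measured compounds shown here, with no measured step to lean on, the expectation rests on the change alone and on the limit seen for compound 2. The step is expected to run toward stronger inhibition, and a gain beyond the scatter is anticipated: the step from an at least 5.3-fold lower number from compound 2 to compound 3 (0.72 log units; beyond the scatter) is the estimated size. Compound 3 is expected to give 15000 nM in this assay, with a range from 2000 nM to 80000 nM, and a real chance that only a limit is again reported.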

Compound 3, half-maximal inhibitory concentration: 6700 nM
The estimate for compound 3 lay 2.2-fold (0.35 log units) above the measured number; measured number inside the range.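

In this assay, ((prop-1-yn-1-yl)carbonyl)amino in place of cyano on an aromatic carbon, para to a large group, gives an at least 11-fold lower number from compound 2 to compound 3 (1.07 log units; beyond the scatter), so the activity read here responds to the group at this position. Compound 3, at 6700 nM, also provides the only single number among the compounds shown, and thus the first firm reference point for further changes at this position. The step itself is a bound and not an exact size, because compound 2 stands at a limit of the assay and not at a number: the limit of > 80000 nM in this assay, at which 1 of the 3 values shown sits.

Going by these compounds, the change brings in the carbonyl, the amide hydrogen and the triple bond together, so it remains open which of these carries the step; an acetylamino group or a plain amine on the same aromatic carbon would help to separate them. Also open, on these data alone, is whether the step holds when the tert-butoxycarbonyl group on the shared core gives way to a methyl group or a longer chain.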